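The source may report more compounds than this note shows. Statements on the series, on what has been measured and on what is new or still open speak of the compounds shown alone.

Measured so far in an ADME assay on Vero cells (Chlorocebus sabaeus) for cytotoxicity, read by CellTiter-Glo, with a stated time of 72 h; on this read-out lower numbers stand for higher toxicity in this test and higher numbers for lower toxicity in this test:
- compound 1 `[O-][n+]1nc(NC2CCC2)[n+]([O-])c2ccccc21`: 8.9 ug/mL
- compound 2 `[O-][n+]1nc(NC2CCCCC2)[n+]([O-])c2ccccc21`: 8.9 ug/mL

Among the measured compounds shown here, with only two measurements, there is little to place compound 2 against. It stands level with compound 1, its nearest and only neighbour, and compound 2 reads 8.9 ug/mL.

The next compound, compound 3 `CCCC(C)Nc1n[n+]([O-])c2ccccc2[n+]1[O-]`, keeps the shared core and replaces one group: 1-methylbutyl in place of cyclohexyl on a nitrogen on an aromatic ring.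

Just one measured step bears on this change: no change at the digits printed from compound 1 to compound 2 (within the scatter). That step exchanged one carbon ring for another and left the reading untouched. For the measured compounds named here, it is only indirect evidence, since 1-methylbutyl has no ring and no compound without a ring on this nitrogen has been tested. Going by the values given here, a surprise in either direction therefore cannot be ruled out, but nothing measured so far points to a shift in this assay, so no direction is favoured.

The expected result is no change at the digits printed from compound 2 to compound 3 (within the scatter), which would lie within the scatter. For compound 3 the estimated value is 8.9 ug/mL, with an expected range of 4 ug/mL to 20 ug/mL.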

Compound 3, half-maximal cytotoxic concentration: 26 ug/mL
Compound 3: middle estimate off by 2.9-fold (0.47 log units), on the low side; the whole stated range lies below it.
By their numbers in this assay, from the lowest: compounds 1 and 2 (each within the scatter of the next); then compound 3.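

In this assay, the group on the nitrogen can move the reading after all: swapping cyclohexyl for the open-chain 1-methylbutyl gives a 2.9-fold higher number from compound 2 to compound 3 (0.47 log units; beyond the scatter), and the same holds against the smaller ring, with a 2.9-fold higher number from compound 1 to compound 3 (0.47 log units; beyond the scatter), both beyond the usual scatter of the test. Among the compounds shown here, the earlier pair showed only that cyclobutyl and cyclohexyl read alike, so compound 3 is the first sign that this position is not indifferent to what sits on it, and that the size of a carbon ring there is not the whole story. Nothing available explains why the open chain reads higher.

The compounds shown leave open whether the ring's absence or the branch on the chain goes with the higher number, a question that a straight pentyl chain and a cyclopentyl group on the same nitrogen could help to separate. They also say nothing about how a chain ending in an amine or a hydroxyl group would read at this position, since every group shown here is made of carbon only.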